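This account rests on a few compounds, and the source may have more. Where it says the series, first, only, none or still open, it means among the compounds named here.

Measured so far:
compound 1 `N#CC1=C(N)N(c2ccc(S(N)(=O)=O)cc2)C2=C(C(=O)CCC2)C1c1ccc(Cl)cc1Cl` gives 65%
compound 2 `N#CC1=C(NC(=O)/C=C/c2ccccc2)N(c2ccc(S(N)(=O)=O)cc2)C2=C(C(=O)CCC2)C1c1ccc(Cl)cc1Cl` gives 40%

Both were run in a functional assay on Ehrlich cells (Mus musculus) for cytotoxicity, read by trypan blue exclusion, with a stated time of 2 h, tested at 50 ug/mL; on this read-out higher numbers stand for a stronger effect at the one concentration tested and lower numbers for a weaker effect. Compound 2 stands lowest of the two numbers; its nearest neighbour is compound 1, and the step of a number 25 percentage points lower from compound 1 to compound 2 (beyond the scatter) is beyond the scatter, modest in size. That step replaced hydrogen on the amine nitrogen with (2-phenylethenyl)carbonyl.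

Compound 3 `N#CC1=C(NC(=O)c2ccc([N+](=O)[O-])cc2)N(c2ccc(S(N)(=O)=O)cc2)C2=C(C(=O)CCC2)C1c1ccc(Cl)cc1Cl` is not yet measured. Its difference from compound 2 is 4-nitrophenyl in place of 2-phenylethenyl on a carbonyl carbon. Going by the values given here, no measured step swaps one group for another on this carbonyl carbon, so the only step that bears on it does so indirectly: it shows that adding a carbonyl-bearing group at the amine nitrogen lowered the number, but says nothing about exchanging one such group for another. The expectation is therefore a step of a number 2 percentage points higher from compound 2 to compound 3 (within the scatter), close to none beyond the scatter, with wide uncertainty. For compound 3 the estimate in this assay is 42%, within 25% to 60%.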

Compound 3, a percentage reported as activity, at one concentration (the size of the read-out at that concentration, not a potency): 50%
Beside the measured number, compound 3's estimate is 8 percentage points below it, within the range that was stated.
By their numbers in this assay, from the lowest: compounds 2 and 3 (each within the scatter of the next); then compound 1.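

In this assay, 4-nitrophenyl in place of 2-phenylethenyl on a carbonyl carbon gives a number 10 percentage points higher from compound 2 to compound 3 (within the scatter), so this exchange of one aromatic group for another does not separate the two amides. (4-Nitrophenyl)carbonyl in place of hydrogen on an amine nitrogen gives a number 15 percentage points lower from compound 1 to compound 3 (beyond the scatter), making this the second group at that nitrogen, after (2-phenylethenyl)carbonyl, to give a lower number than the free amine of compound 1, with neither of the two going against this pattern. No available evidence explains either step.

From the compounds shown here alone, whether a small acetyl group or a saturated chain on the carbonyl carbon would give the same drop remains open. So does whether an amine or a carboxylic acid in place of the nitro group on the phenyl ring would change the number.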